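One Ring Group Exchanged on a Shared Core

The source may hold more compounds than are shown below. What is called first, only, known or untested is meant among the compounds shown, and "the series" means these compounds.

Of the compounds shown here, two with the same core have been measured so far in a functional assay on K562 cells (Homo sapiens) for inhibition, read by trypan blue exclusion, with a stated time of 72 h; on this read-out lower numbers stand for stronger inhibition and higher numbers for weaker inhibition. There, compound 1 `Cn1c(=O)c(S(=O)(=O)c2ccc(Cl)cc2)cc2cnc(Nc3cccc4[nH]ccc34)nc21` gives 5000 nM. Compound 2 `Cn1c(=O)c(S(=O)(=O)c2ccc(Cl)cc2)cc2cnc(Nc3cnc4[nH]ccc4c3)nc21` gives 5000 nM, which places it level with compound 1.

The next compound is compound 3 `Cn1c(=O)c(S(=O)(=O)c2ccc(Cl)cc2)cc2cnc(Nc3cnc4ccccc4c3)nc21`, and its change from compound 2 is this: a group of 10 heavy atoms (9 carbon, 1 nitrogen; one six-membered aromatic ring of carbon only, one six-membered aromatic ring with 1 hetero atom) in place of a group of 9 heavy atoms (7 carbon, 2 nitrogen; one five-membered aromatic ring with 1 hetero atom, one six-membered aromatic ring with 1 hetero atom), on a nitrogen on an aromatic ring. The incoming group is quinolin-3-yl, attached on a nitrogen on an aromatic ring.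

Within the data shown here, only one measured step bears on this change, because it replaced a group at that same place: no change at the digits printed from compound 1 to compound 2 (within the scatter). That single step is a thin guide. Among the measured compounds shown here, both of its groups contain a five-membered aromatic ring, whereas quinolin-3-yl contains none, so no measured compound tests this particular exchange.

With nothing else to go on, the flat result of that one step is carried forward, and no shift beyond the scatter is expected in this assay. The expected step is no change at the digits printed from compound 2 to compound 3 (within the scatter). Compound 3 is estimated at 5000 nM, with an expected range from 2000 nM to 10000 nM.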

Compound 3, half-maximal inhibitory concentration: 15000 nM
Estimate against measurement, compound 3: 3.0-fold (0.48 log units) below; the whole stated range lies below it.
By their numbers in this assay, from the lowest: compounds 1 and 2 (each within the scatter of the next); then compound 3.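

This step shows that the group on this nitrogen can change the read-out, which the flat step between compounds 1 and 2 did not reveal. In this assay, quinolin-3-yl gives a 3.0-fold higher number from compound 2 to compound 3 (0.48 log units; beyond the scatter), and against 1H-indol-4-yl it gives a 3.0-fold higher number from compound 1 to compound 3 (0.48 log units; beyond the scatter), so on this read-out it is the weakest of the three, though only modestly. Both groups with a five-membered aromatic ring and 1 hydrogen-bond donor sit level, while quinolin-3-yl has two six-membered aromatic rings and 0 hydrogen-bond donors, but the data cannot separate these two differences, and no measured evidence explains the shift.

The compounds shown leave open whether the donor count or the ring size matters more here, and whether a smaller group such as plain phenyl, or a phenyl carrying a piperazine, would give a lower number at this place. With the rest of the shared core held fixed throughout, they also leave open how a change elsewhere, such as an amine in place of the chlorine on the 4-chlorophenyl ring, would read in this assay.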